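The source may report more compounds than this note shows. Statements on the series, on what has been measured and on what is new or still open speak of the compounds shown alone.

Measured so far:
compound 1, `O=C(O)c1cn(Cc2cc(Br)ccc2OCc2ccccc2)nn1`, < 2000 nM
compound 2, `Cc1cc(C(=O)O)nn1Cc1cc(Br)ccc1OCc1ccc(Cl)cc1Cl`, 0.49 nM

In a functional assay on CHO-K1 cells for antagonist activity at prostaglandin E2 receptor EP1 subtype (Homo sapiens), read by FLIPR (on this read-out higher numbers stand for weaker inhibition and lower numbers for stronger inhibition), compound 1 gives < 2000 nM, which is a limit of the assay and not a number (the limit of < 2000 nM in this assay, at which 1 of the 2 values shown sits). Compound 2 gives 0.49 nM in this assay, the only number shown in the series. Compound 3, `COc1ccccc1COc1ccc(Br)cc1Cn1nc(C(=O)O)cc1C`, is not yet measured; it differs from compound 2 by 2-methoxyphenyl in place of 2,4-dichlorophenyl on a saturated chain carbon bound to an oxygen on an aromatic ring. Among the measured compounds shown here, no measured step covers such a change, so the expected step from compound 2 to compound 3 of a 10-fold higher number from compound 2 to compound 3 (1.01 log units; beyond the scatter) in this assay rests on the change alone and is expected to weaken inhibition beyond the scatter. Compound 3 is estimated at 5 nM, within 1 nM to 30 nM.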

Compound 3, inhibition constant: 69.2 nM
Compound 3: middle estimate off by 14-fold (1.14 log units), on the low side, outside the stated range (above it).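

In this assay, 2-methoxyphenyl in place of 2,4-dichlorophenyl on a saturated chain carbon bound to an oxygen on an aromatic ring gives a 140-fold higher number from compound 2 to compound 3 (2.15 log units; beyond the scatter), so inhibition at this position depends strongly on the group it carries. Compound 3 still gives a number, 69.2 nM, and not a limit. Nothing shown gives a cause for this step.

Open, on these data alone, is whether a phenyl carrying a single chlorine would stay close to compound 2 or fall towards compound 3. Also open, as far as these compounds go, is how a plain phenyl would read on the same core.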